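The source may hold more compounds than are shown below. What is called first, only, known or untested is meant among the compounds shown, and "the series" means these compounds.

Three compounds have so far been measured in a functional assay on HL-60 cells (Homo sapiens), with a stated time of 48 h; on this read-out lower numbers stand for an effect already at smaller amounts and higher numbers for an effect only at larger amounts of compound:

compound 1 `CC1(C)CCC(C)(C)c2cc(/C=C/c3ccc(N)cc3)ccc21`: 38000 nM
compound 2 `CC1(C)CCC(C)(C)c2cc(/C=C/c3cccc(N)c3)ccc21`: 40000 nM
compound 3 `C/C(=C/c1ccccc1C(=O)O)c1ccc2c(c1)C(C)(C)CCC2(C)C`: 90000 nM

Compound 2 stands second highest of these three numbers. Within the data shown here, its value and that of compound 1 lie within the scatter of each other, the only single-point step among them being a 1.1-fold higher number from compound 1 to compound 2 (0.02 log units; within the scatter). Compound 3 gives the highest number of the set, and its distance from compound 2 is beyond the scatter.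

The next compound, compound 4 `COc1ccc(/C=C/c2ccc3c(c2)C(C)(C)CCC3(C)C)cc1N`, is derived from compound 2 by a single change: methoxy in place of hydrogen on an aromatic carbon. The amino group itself stays where it is in compound 2.

Among the measured compounds shown here, no measured step bears directly on this change. For the measured compounds named here, the one step that exists, a 1.1-fold higher number from compound 1 to compound 2 (0.02 log units; within the scatter), concerns where the amino group sits on the ring, not the addition of a methoxy group, and it was within the scatter. Nothing in the measured set shows what a methoxy group does in this assay. With no guidance in either direction, the expectation for compound 4 is a step of about no change at the digits printed from compound 2 to compound 4 (within the scatter), that is, none beyond the scatter. Compound 4 is therefore estimated at 40000 nM, within a range of 15000 nM to 100000 nM.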

Compound 4, concentration for half-maximal activity: 85000 nM
For compound 4 the middle estimate is 2.1-fold (0.33 log units) below the measured one, within the range that was stated.
By their numbers in this assay, from the lowest: compounds 1 and 2 (each within the scatter of the next); then compounds 4 and 3 (each within the scatter of the next).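

In this assay the addition of methoxy on an aromatic carbon, ortho to an amino group and para to a large group, gives a 2.1-fold higher number from compound 2 to compound 4 (0.33 log units; beyond the scatter) and so moves the number towards larger amounts of compound. Among these compounds, this modest step is the first single change to go beyond the scatter, whereas moving the amino group around the ring gave a 1.1-fold higher number from compound 1 to compound 2 (0.02 log units; within the scatter) and stayed within it. The ring position taken up by methoxy therefore responds to substitution in a way the earlier pair could not reveal, although nothing given here explains the step.

As far as these compounds go, whether a hydroxyl group, an ethoxy group or a fluorine atom on the same aromatic carbon would shift the number in the same direction and by a similar amount remains open, as does whether methoxy would have the same result on the ring of compound 1. Also open, from the compounds shown here alone, is whether an acetamide or a carboxylic acid in place of the amino group of compound 4 would retain, raise or lower its number.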